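A few compounds are considered here, and "the series" means these few. Any claim that something is new, unique, unknown or untested is made for them only; others in the source may bear on it.

Of the compounds shown here, two from this series share one core and have been tested in a functional assay on HepG2 cells (Homo sapiens) for cytotoxicity, read by MTT assay, with a stated time of 48 h; a higher number here means a weaker inhibitor, a lower number a stronger inhibitor. Compound 1 `Cc1nnc(SCC(=O)c2ccc(Cl)cc2)n1N1C(=O)c2ccccc2C1=O` carries a (4-chlorophenyl)carbonyl group on a saturated chain carbon bound to a sulfur. In this assay compound 1 reaches only the limit of the assay, > 200000 nM. Compound 2 `C#CCSc1nnc(C)n1N1C(=O)c2ccccc2C1=O` carries an ethynyl in that place. In this assay compound 2 likewise reaches only the limit, > 200000 nM. The step that the two limits leave unreadable from compound 1 to compound 2 is therefore unreadable, since the limit of > 200000 nM in this assay, at which 2 of the 2 values shown sit, holds both values.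

Compound 3 `CSc1nnc(C)n1N1C(=O)c2ccccc2C1=O` differs from compound 2 by hydrogen in place of ethynyl on a saturated chain carbon bound to a sulfur. Among the measured compounds shown here, the one measured step bears on this change only loosely, and its size is not readable, so there is no basis for expecting any shift beyond the scatter in either direction. Given that compound 2 stands at the limit, the step from compound 2 to compound 3 is expected to be a step that the limit leaves unreadable from compound 2 to compound 3, and compound 3 is expected to sit at about 300000 nM, within 150000 nM to 1000000 nM, most probably again as a limit.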

Compound 3, half-maximal inhibitory concentration: > 200000 nM
Compound 3 ended at the assay's limit; the forecaster's own chance of this, stated with the estimate: 85%; the middle value is on the limit's open side.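

No new step can be read in this assay between compound 3 and compound 2 or compound 1, since all three compounds rest on one limit: the limit of > 200000 nM in this assay, at which 3 of the 3 values shown sit. The compounds shown leave open how far each lies past that limit, and whether any change on the saturated chain carbon bound to a sulfur affects the value.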